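A few compounds are considered here, and "the series" means these few. Any claim that something is new, unique, unknown or untested is made for them only; others in the source may bear on it.

Measured compounds in a functional assay on A549 cells (Homo sapiens) for antiproliferative activity, read by MTT assay, with a stated time of 24 h; a lower number here means a stronger inhibitor, a higher number a weaker inhibitor: compound 1 `O=c1[nH]cc(S(=O)(=O)Nc2cccc(-c3cn(-c4ccccc4)nn3)c2)c(=O)[nH]1` gives 12700 nM; compound 2 `Cc1cccc(-n2cc(-c3cccc(NS(=O)(=O)c4c[nH]c(=O)[nH]c4=O)c3)nn2)c1` gives 3550 nM; compound 3 `O=c1[nH]cc(S(=O)(=O)Nc2cccc(-c3cn(-c4cccc(F)c4)nn3)c2)c(=O)[nH]1` gives 7200 nM.

Compound 3 stands second highest of the three numbers. Compound 1 is within the scatter of it, the step being a 1.8-fold lower number from compound 1 to compound 3 (0.25 log units; within the scatter), while compound 2 sits further off, with a 2.0-fold higher number from compound 2 to compound 3 (0.31 log units; beyond the scatter). Compound 4 `O=c1[nH]cc(S(=O)(=O)Nc2cccc(-c3cn(-c4ccccc4Cl)nn3)c2)c(=O)[nH]1` differs from compound 3 by 2-chlorophenyl in place of 3-fluorophenyl on an aromatic nitrogen. Going by the values given here, no measured step touches a chlorine or this place on the ring; the only steps on this ring are a 1.8-fold lower number from compound 1 to compound 3 (0.25 log units; within the scatter) and a 3.6-fold lower number from compound 1 to compound 2 (0.55 log units; beyond the scatter), both small. A step in this assay is therefore expected to be small or none beyond the scatter. Compound 4 is expected to give about 7000 nM, between 2500 nM and 20000 nM. That estimate means a 1.0-fold lower number from compound 3 to compound 4 (0.01 log units; within the scatter).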

Compound 4, half-maximal inhibitory concentration: 2730 nM
Beside the measured number, compound 4's estimate is 2.6-fold (0.41 log units) above it; the range from low to high includes it.
By their numbers in this assay, from the lowest: compounds 4 and 2 (each within the scatter of the next); then compounds 3 and 1 (each within the scatter of the next).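

In this assay the 2-chlorophenyl group on the aromatic nitrogen separates from the 3-fluorophenyl group (a 2.6-fold lower number from compound 3 to compound 4 (0.42 log units; beyond the scatter)), and chloro in place of hydrogen on the ring gives a step of similar modest size (a 4.7-fold lower number from compound 1 to compound 4 (0.67 log units; beyond the scatter)). Against the 3-methylphenyl group the change cannot be told apart (a 1.3-fold lower number from compound 2 to compound 4 (0.11 log units; within the scatter)), so two different substituents reach the same level. No measurement here accounts for these steps. The compounds shown leave open whether the step follows the chlorine or its place on the ring, and how a 2-methoxyphenyl or 2-aminophenyl group would read.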